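A few compounds are considered here, and "the series" means these few. Any claim that something is new, unique, unknown or untested is made for them only; others in the source may bear on it.

Compound 3 `O=C1/C(=C/c2ccccc2)C(c2ccccc2)Oc2ccccc21` gives 3.9 in a physicochemical assay for lipophilicity, read by HPLC; on this read-out higher numbers stand for higher lipophilicity and lower numbers for lower lipophilicity. In this assay compound 2 `O=C1/C(=C\c2ccccc2)C(c2ccccc2)Oc2ccccc21` gives 3.9, and compound 1 `O=C1/C(=C/c2ccncc2)C(c2ccccc2)Oc2ccccc21` gives 2.98. Compound 3 is level with compound 2 at the digits shown, the two together being the highest of the three numbers; compound 1 lies furthest from it. Between compound 2 and compound 3 there is no change at the digits printed from compound 2 to compound 3 (within the scatter), which fits (the fact that one of compounds 2 and 3 is drawn with a defined configuration and the other without, at the place where they differ). The step of a number 0.92 log units higher from compound 1 to compound 3 (beyond the scatter) puts phenyl in place of pyridin-4-yl on the double-bonded chain carbon.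

Compound 4 `O=C1/C(=C/c2ccccc2)C(c2ccccc2)Oc2ccc(O)cc21` is not yet measured. It differs from compound 3 by hydroxy in place of hydrogen on an aromatic carbon. Neither of the two measured steps puts a hydroxy in place of a hydrogen on any ring, so none bears directly on this change. The step from compound 1 to compound 3 shows that the numbers in this assay move beyond the scatter when a ring is exchanged, while a change in drawn configuration alone leaves them within it. For compound 4, with a hydroxy entering as one hydrogen-bond donor and one acceptor on the fused aromatic ring, a modest downward step a number 0.60 log units lower from compound 3 to compound 4 (beyond the scatter) is expected. The estimate for compound 4 is 3.3, expected to lie between 2.8 and 3.8.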

Compound 4, partition coefficient: 3.5
Compound 4: middle estimate off by 0.20 log units, on the low side, and the stated range covers the measured number.
By their numbers in this assay, from the lowest: compound 1; then compound 4; then compounds 2 and 3 (each within the scatter of the next).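

Hydroxy in place of hydrogen on an aromatic carbon gives a number 0.40 log units lower from compound 3 to compound 4 (beyond the scatter), so a change on the six-membered aromatic ring of carbon only, part of the fused system, moves the number in this assay beyond the scatter. For the compounds shown here, until now, the only step beyond the scatter was the exchange of the ring on the double-bonded chain carbon, a number 0.92 log units higher from compound 1 to compound 3 (beyond the scatter). The new step instead leaves that phenyl and the drawn configuration of compound 3 untouched, alters the shared core itself and enters 1 hydrogen-bond donor and 1 hydrogen-bond acceptor, but nothing at hand bears on why the number moves with this change.

From the compounds shown here alone, whether the step belongs to hydroxy itself remains open, since a methoxy group, an amine or a fluorine on the same aromatic carbon would separate the effect of the group from that of the place, and hydroxy on another carbon of this ring would show how much the place matters. Also open, going by these compounds, is whether the same change gives a similar step with pyridin-4-yl on the chain carbon, as in compound 1, or with the double bond drawn Z, as in compound 2.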